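The source may report more compounds than this note shows. Statements on the series, on what has been measured and on what is new or still open speak of the compounds shown alone.

In an ADME assay on Vero 76 cells (Chlorocebus sabaeus) for cytotoxicity, read by MTT assay, with a stated time of 96 h (on this read-out lower numbers stand for higher toxicity in this test and higher numbers for lower toxicity in this test), compound 3 `NS(=O)(=O)c1ccc(N2N=C(c3ccc(OCc4ccccc4)cc3)CC2c2ccccc2F)cc1` reports only a limit, > 100000 nM. Compound 1 `NS(=O)(=O)c1ccc(N2N=C(c3ccc(OCc4ccccc4)cc3)CC2c2ccccc2)cc1` also reports only a limit, > 100000 nM. Compound 2 `NS(=O)(=O)c1ccc(N2N=C(c3ccc(OCc4ccccc4)cc3)CC2c2ccc(Cl)cc2)cc1` gives a measured number, 82000 nM. Compound 4 `Cc1cccc(C2CC(c3ccc(OCc4ccccc4)cc3)=NN2c2ccc(S(N)(=O)=O)cc2)c1` carries 3-methylphenyl in place of 2-fluorophenyl on a saturated ring carbon. Three measured changes at this same place bear on it: an at least 1.2-fold lower number from compound 1 to compound 2 (0.08 log units; that floor lies within the scatter), an at least 1.2-fold higher number from compound 2 to compound 3 (0.08 log units; that floor lies within the scatter), and a step that the two limits leave unreadable from compound 1 to compound 3. None of them shows a step beyond the scatter, so none beyond the scatter is expected in this assay here, and another limit reading is quite possible. The expected change is an at least 1.1-fold lower number from compound 3 to compound 4 (0.04 log units; that floor lies within the scatter). Compound 4 is estimated at 90000 nM, with an expected range from 50000 nM to 160000 nM.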

Compound 4, half-maximal cytotoxic concentration: 100000 nM
Estimate against measurement, compound 4: 1.1-fold (0.05 log units) below, within the range that was stated.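

In this assay, 3-methylphenyl in place of 4-chlorophenyl on this saturated ring carbon gives a 1.2-fold higher number from compound 2 to compound 4 (0.09 log units; within the scatter). The other two changes give a number no higher from compound 3 to compound 4 (the limit leaves the size open) and a number no higher from compound 1 to compound 4 (the limit leaves the size open), and the size of these two steps cannot be read. A methyl on this phenyl ring therefore shows no readable step beyond the scatter, and the top of what this test can report is reached here: the limit of > 100000 nM in this assay, at which 2 of the 4 values shown sit.

Still open, going by these compounds, is whether an amine or a carboxylic acid on this phenyl ring would give a step beyond the scatter.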